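Removing an Acetyl Group: Expected Cytotoxicity of Compound 3

The source may hold more compounds than are shown below. What is called first, only, known or untested is meant among the compounds shown, and "the series" means these compounds.

Measured compounds:
compound 1 `COc1ccc(NC(=O)/C=C/C(=O)N2C/C(=C\c3ccc([N+](=O)[O-])cc3)C(=O)/C(=C/c3ccc([N+](=O)[O-])cc3)C2)cc1` — 940 nM
compound 2 `CC(=O)c1ccc(NC(=O)/C=C/C(=O)N2C/C(=C\c3ccccc3)C(=O)/C(=C/c3ccccc3)C2)cc1` — 1400 nM

Of the compounds shown here, two have so far been tested in a functional assay on Molt4/C8 cells (Homo sapiens) for cytotoxicity; on this read-out lower numbers stand for stronger inhibition and higher numbers for weaker inhibition. Compound 1 gives 940 nM and compound 2 gives 1400 nM; the gap between the two numbers lies within the usual scatter of the assay, so neither compound can be called the more potent of the pair. The two structures differ in more than one place, so no single structural step can be read from them.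

Compound 3 `O=C(/C=C/C(=O)N1C/C(=C\c2ccccc2)C(=O)/C(=C/c2ccccc2)C1)Nc1ccccc1` has not yet been measured. It differs from compound 2 in one place: hydrogen in place of acetyl on an aromatic carbon. Among the measured compounds shown here, no measured pair shows what such a change does. Because compound 2 stands at 1400 nM and nothing in the data points in either direction, the step implied by the estimate is a 1.1-fold higher number from compound 2 to compound 3 (0.06 log units; within the scatter), expected to be small and not beyond the scatter. Compound 3 is thus expected to give about 1600 nM in this assay, with a likely range from 600 nM to 4500 nM.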

Compound 3, half-maximal inhibitory concentration: 520 nM
Compound 3: the middle estimate sits 3.1-fold (0.49 log units) above what was measured; the measured number lies below the stated range.
By their numbers in this assay, from the lowest: compounds 3, 1 and 2 (each within the scatter of the next, the first and the last beyond it).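

In this assay, among the compounds shown here, the change from 4-acetylphenyl to phenyl brings a 2.7-fold lower number from compound 2 to compound 3 (0.43 log units; beyond the scatter) and so gives the first reading of a single structural change. At this place on the ring, para to a large group, the acetyl group is not needed for cytotoxicity, and the compound with hydrogen there inhibits more strongly than the one with acetyl. Nothing shown here explains why the number falls when the acetyl group leaves.

On these data alone, it remains open whether a different group at this same place, such as an amine, a carboxylic acid or a fluorine atom, would match hydrogen or fall back towards acetyl. Compound 1 differs from compound 3 in more than one place, so the separate contributions of its methoxy and nitro groups cannot be read.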